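The compounds below may be only part of what the source reports. "The series", "measured", "known", "first", "only" and "open" are said of these compounds alone.

Series notes. Three amides sharing one core have been run in a functional assay on HEK293 cells for positive allosteric modulation of metabotropic glutamate receptor 5 (Rattus norvegicus), read by fluorescence and calcium flux; on this read-out higher numbers stand for an effect only at larger amounts of compound and lower numbers for an effect already at smaller amounts. Compound 1 `O=C(COCc1ccccc1)N1CCN(c2ncccc2C(F)(F)F)CC1` gives 4300 nM. Compound 2 `O=C(COCc1ccccc1)N1CCN(c2cccnc2)CC1` gives "not active" (no number reported). Compound 3 `COc1ccccc1N1CCN(C(=O)COCc2ccccc2)CC1` gives 9200 nM, the highest of the two reported numbers; its nearest neighbour is compound 1, whose number sits lower by a margin beyond the usual scatter, while compound 2 returned no number at all. Going by the values given here, no two measured compounds differ in a single place, so no measured step exists in this set. Compound 4 `COC(=O)c1ccccc1N1CCN(C(=O)COCc2ccccc2)CC1` carries the change (methoxycarbonyl in place of methoxy on an aromatic carbon). Among the compounds with values here, with no measured step to lean on, the step expected in this assay is a 1.1-fold higher number from compound 3 to compound 4 (0.04 log units; within the scatter), either within the scatter or drifting upward. Compound 4 is estimated at 10000 nM, with a range from 3500 nM to 30000 nM, and a real chance that no number is reported.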

Compound 4, half-maximal effective concentration: > 10000 nM
Compound 4: a limit, no number; the forecaster's own chance of this, stated with the estimate: 35%; the middle value sits exactly at the limit.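

Compound 4 gives a limit of the assay, not a number. Methoxycarbonyl in place of methoxy on an aromatic carbon, ortho to a large group, can be read only as a floor, an at least 1.0-fold higher number from compound 3 to compound 4 (0.03 log units; that floor lies within the scatter), and nothing in this assay points to a lower number for the larger group at this position. The true size of the step stays hidden at the edge of the read-out: the limit of > 10000 nM in this assay, at which 1 of the 4 values shown sits.

As far as these compounds go, how far the step reaches above that floor stays open. Also open, from the compounds shown here alone, is whether an amine, a primary amide or a carboxylic acid on this carbon gives a lower number than methoxy.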